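A benzyl swap on the weaker fluoro compound

A few compounds are considered here, and "the series" means these few. Any claim that something is new, unique, unknown or untested is made for them only; others in the source may bear on it.

Measured so far in a functional assay on PC-3 cells (Homo sapiens) for cytotoxicity, read by MTT assay, with a stated time of 48 h; a lower number here means a stronger inhibitor, a higher number a weaker inhibitor:
compound 1 `Cc1ccc(Cn2c(/C=C3\SC(=S)N(CC(=O)O)C3=O)nc3ccc(Cl)cc32)cc1`: 1520 nM
compound 2 `Cc1ccc(Cn2c(/C=C3\SC(=S)N(CC(=O)O)C3=O)nc3ccc(F)cc32)cc1`: 5820 nM

Compound 2 holds the higher of the two numbers, which makes it the weaker inhibitor of the pair. Compound 3 `O=C(O)CN1C(=O)/C(=C/c2nc3ccc(F)cc3n2Cc2ccccc2F)SC1=S` keeps the fluoro of compound 2 but carries 2-fluorophenyl in place of 4-methylphenyl on a saturated chain carbon bound to an aromatic nitrogen. Among the compounds with values here, the only measured step, a 3.8-fold higher number from compound 1 to compound 2 (0.58 log units; beyond the scatter), is modest and beyond the scatter, but it concerns fluoro in place of chloro on an aromatic carbon, not this group. Within the data shown here, it bears on the change only loosely, and no measured step touches the group that changes. A small step in this assay, with no clear direction, is therefore expected. The estimated step is a 1.2-fold lower number from compound 2 to compound 3 (0.07 log units; within the scatter). For compound 3 the estimated value is 5000 nM, with an expected range from 2000 nM to 12000 nM.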

Compound 3, half-maximal inhibitory concentration: > 50000 nM
Compound 3: no number, only a limit; the forecaster's own chance of this, stated with the estimate: 3%; at least 10-fold (1.00 log units) between middle value and limit.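

In this assay, the position on the saturated chain carbon bound to an aromatic nitrogen proves far from silent: 2-fluorophenyl in place of 4-methylphenyl there gives an at least 8.5-fold higher number from compound 2 to compound 3 (0.93 log units; beyond the scatter), whereas the earlier compounds had shown only a change of halogen on an aromatic carbon. On these data alone, compound 3 gives > 50000 nM, which is a limit of the assay and not a number, so the full size of this step stays unknown. This limit is the only evidence on compound 3 in the series: the limit of > 50000 nM in this assay, at which 1 of the 3 values shown sits.

The compounds shown do not separate the loss of the methyl group from the gain of the fluorine, and they do not show whether the step would hold with chloro in place of fluoro on the core. As far as these compounds go, whether plain benzyl, 4-fluorobenzyl or a longer chain such as phenethyl would stay near compound 2 also remains open.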